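Huh-7 tolerance across ring-nitrogen substituents on the shared core

The compounds below may be only part of what the source reports. "The series", "measured", "known", "first", "only" and "open" are said of these compounds alone.

Measured so far in an ADME assay on Huh-7 cells (Homo sapiens) for cytotoxicity, with a stated time of 72 h; a higher number here means that more compound is tolerated, a lower number that less compound is tolerated:
- compound 1 `CCN1C(=O)C(C2=NS(=O)(=O)c3cc(NS(C)(=O)=O)ccc3N2)=C(O)C2CCCC21`: > 33000 nM (a limit of this assay, not a number)
- compound 2 `CS(=O)(=O)Nc1ccc2c(c1)S(=O)(=O)N=C(C1=C(O)C3CCCC3N(c3ccccc3)C1=O)N2`: "not determined" (no result reported)

Compound 2 stands without a number in this assay. Within the data shown here, the only value shown for the series is the limit of > 33000 nM in this assay, at which 1 of the 2 values shown sits, a limit rather than a measured concentration. Among the measured compounds shown here, no step between measured compounds exists, so the size of a change on this assay cannot be read from the data.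

Compound 3 `CS(=O)(=O)Nc1ccc2c(c1)S(=O)(=O)N=C(C1=C(O)C3CCCC3N(Cc3cccc(F)c3)C1=O)N2` differs from compound 2 by 3-fluorobenzyl in place of phenyl on an amide-type nitrogen in a ring. For the measured compounds named here, with no measured step to rest on, the expectation for this assay is that compound 3 behaves like compound 1, which sits at the limit, and that no change beyond the scatter appears in either direction. Compound 3 is therefore estimated at 30000 nM in this assay, within 10000 nM to 33000 nM, most likely reported again only as a limit.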

Compound 3, half-maximal cytotoxic concentration: > 33000 nM
Compound 3 gave a limit, no number (the forecaster's own chance of this, stated with the estimate: 70%); at least 1.1-fold (0.04 log units) between middle value and limit.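

No step from compound 1 to compound 3 can be read in this assay, since both compounds sit at a limit and not at a number: the limit of > 33000 nM in this assay, at which 2 of the 3 values shown sit.

The compounds shown leave open whether the substituents on the amide-type ring nitrogen differ at all in half-maximal cytotoxic concentration.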